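The source may hold more compounds than are shown below. What is called first, only, known or untested is meant among the compounds shown, and "the series" means these compounds.

Three compounds share one core and differ only in the aryl group on the carbon that is double-bonded to nitrogen. Compound 1 `CN(C)CCn1cnnc1-c1cc(Oc2ccc(NC(=O)N/N=C/c3c(Cl)cccc3Cl)cc2F)ccn1` gives 280 nM in a functional assay on HT-29 cells (Homo sapiens) for cytotoxicity, read by MTT assay, with a stated time of 72 h; on this read-out lower numbers stand for stronger inhibition and higher numbers for weaker inhibition. Compound 2 `CN(C)CCn1cnnc1-c1cc(Oc2ccc(NC(=O)N/N=C/c3ccc(O)c(Br)c3)cc2F)ccn1` gives 450 nM in this assay, and compound 3 `CN(C)CCn1cnnc1-c1cc(Oc2ccc(NC(=O)N/N=C/c3ccc(Cl)cc3)cc2F)ccn1` gives 530 nM. Compound 3 holds the highest of the three numbers, yet both its nearest neighbour and its furthest lie within the scatter of it: a 1.2-fold higher number from compound 2 to compound 3 (0.07 log units; within the scatter) and a 1.9-fold higher number from compound 1 to compound 3 (0.28 log units; within the scatter). The remaining step, a 1.6-fold higher number from compound 1 to compound 2 (0.21 log units; within the scatter), is likewise within the scatter. Compound 4 `COc1ccc(/C=N/NC(=O)Nc2ccc(Oc3ccnc(-c4nncn4CCN(C)C)c3)c(F)c2)cc1O` has not yet been measured; it arises from compound 3 by the change (3-hydroxy-4-methoxyphenyl in place of 4-chlorophenyl on a carbon with a double bond to nitrogen). All three measured steps bear on this change, since each swaps the aryl group at the same place, and none of them moved the number beyond the scatter. Among the measured compounds shown here, compound 2, which also carries a hydroxyl on that ring, gives 450 nM and is the closest precedent among the three. The step from compound 3 to compound 4 is therefore expected to stay within the scatter, a 1.1-fold lower number from compound 3 to compound 4 (0.03 log units; within the scatter). Compound 4 is estimated to give 500 nM in this assay, with a range from 200 nM to 1300 nM.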

Compound 4, half-maximal inhibitory concentration: 960 nM
The estimate for compound 4 lay 1.9-fold (0.28 log units) below the measured number; low and high end bracket the measured number.
By their numbers in this assay, from the lowest: compounds 1, 2, 3 and 4 (each within the scatter of the next, the first and the last beyond it).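

With the 3-hydroxy-4-methoxyphenyl group, the aryl group on the carbon with a double bond to nitrogen produces the first differences beyond the scatter in this assay: replacing 3-bromo-4-hydroxyphenyl gives a 2.1-fold higher number from compound 2 to compound 4 (0.33 log units; beyond the scatter) and replacing 2,6-dichlorophenyl gives a 3.4-fold higher number from compound 1 to compound 4 (0.54 log units; beyond the scatter) while replacing 4-chlorophenyl gives a 1.8-fold higher number from compound 3 to compound 4 (0.26 log units; within the scatter) and so does not separate the two compounds. The position is therefore not indifferent to the aryl group, although both steps beyond the scatter are modest, and compound 2 and compound 4 show that two rings each carrying a hydroxyl need not read alike. Nothing available explains these differences.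

The compounds shown leave open whether the methoxy group or the hydroxyl of compound 4 matters more for its number, which a 4-methoxyphenyl or a 3-hydroxyphenyl group at this place could separate. They also leave open how this position would respond to a group of another kind, such as a ring bearing a dimethylamino group or a carboxylic acid, or a saturated cyclohexyl ring in place of the aryl ring.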